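This account rests on a few compounds, and the source may have more. Where it says the series, first, only, none or still open, it means among the compounds named here.

Compound 1 `CCn1cnc2ncnc(N)c21` gives > 30000 nM, a limit. Compound 2 `CCCn1cnc2ncnc(N)c21` gives > 30000 nM, a limit. Compound 3 `CC(C)n1cnc2c(N)ncnc21` gives 16000 nM.

In a functional assay on CHO cells for antagonist activity at adenosine receptor A2b (Homo sapiens) (a lower number here means a stronger inhibitor, a higher number a weaker inhibitor), compound 2 stands at the assay limit, and one further value shown is also a limit. Within the data shown here, the only measured step, a step that the two limits leave unreadable from compound 1 to compound 2, cannot be read because of the limit of > 30000 nM in this assay, at which 2 of the 3 values shown sit. Compound 4 `CC(C)n1cnc2ncnc(N)c21` differs from compound 2 by isopropyl in place of propyl on an aromatic nitrogen. Among the measured compounds shown here, no measured step bears readably on this change, so no shift beyond the scatter in this assay can be argued for in either direction. Compound 4 is therefore expected to remain near the limit, a step of a number no higher from compound 2 to compound 4 (the limit leaves the size open). The estimate for compound 4 is 30000 nM, within the range 10000 nM to 100000 nM.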

Compound 4, inhibition constant: > 30000 nM
Compound 4 gave a limit, no number; the forecaster's own chance of this, stated with the estimate: 60%; the middle value lies on the limit itself.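

Compound 4 gives > 30000 nM in this assay, a limit. Its steps from compound 1 and compound 2 therefore cannot be read: the limit of > 30000 nM in this assay, at which 3 of the 4 values shown sit.

The compounds shown leave open whether isopropyl in place of propyl on an aromatic nitrogen changes the inhibition constant at all.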